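From 3-Bromophenyl to 2-Fluorophenyl on the Shared Core

This account rests on a few compounds, and the source may have more. Where it says the series, first, only, none or still open, it means among the compounds named here.

Measured in an ADME assay on Vero 76 cells (Chlorocebus sabaeus) for cytotoxicity, read by crystal violet staining, with a stated time of 96 h; on this read-out higher numbers stand for lower toxicity in this test and lower numbers for higher toxicity in this test:
Compound 1 `FC(F)(F)c1cccc(NC(=S)Nc2ccc(I)cc2)c1`: 9500 nM
Compound 2 `FC(F)(F)c1cccc(NC(=S)Nc2cccc(Br)c2)c1`: 14000 nM

Going by the values given here, compound 2 does not stand apart from compound 1, as the only measured step is a 1.5-fold higher number from compound 1 to compound 2 (0.17 log units; within the scatter). That step exchanged 4-iodophenyl for 3-bromophenyl on an amide-type nitrogen, and the next change falls at that same place. Compound 3 `Fc1ccccc1NC(=S)Nc1cccc(C(F)(F)F)c1` carries 2-fluorophenyl in place of 3-bromophenyl on an amide-type nitrogen. Among the compounds with values here, only the one measured step bears on this change, and no measured compound yet carries 2-fluorophenyl. In this assay, a step beyond the scatter is therefore not expected, and no direction can be assigned. The expected size of the change is a 1.1-fold higher number from compound 2 to compound 3 (0.03 log units; within the scatter). Compound 3 is estimated at 15000 nM, with an expected range from 6000 nM to 40000 nM.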

Compound 3, half-maximal cytotoxic concentration: 64000 nM
Compound 3: the middle estimate sits 4.3-fold (0.63 log units) below what was measured, and the stated range ends below it.
By their numbers in this assay, from the lowest: compounds 1 and 2 (each within the scatter of the next); then compound 3.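

In this assay this place on the amide-type nitrogen proves able to move the number: 2-fluorophenyl in place of 3-bromophenyl gives a 4.6-fold higher number from compound 2 to compound 3 (0.66 log units; beyond the scatter) and, in place of 4-iodophenyl, gives a 6.7-fold higher number from compound 1 to compound 3 (0.83 log units; beyond the scatter) on the same shared core. Compound 3 thus reads as the least toxic of the three in this test, whereas compound 1 and compound 2 remain within the scatter of each other. The entering and leaving groups have the same heavy-atom count and differ in their halogen and its numbered position, and no evidence at hand accounts for the step.

The compounds shown do not separate the halogen from its numbered position, since neither 2-bromophenyl nor 3-fluorophenyl stands among them. On these data alone, how an amine or a methoxy group would read at this place also remains open.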